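The source may report more compounds than this note shows. Statements on the series, on what has been measured and on what is new or still open speak of the compounds shown alone.

Compound 2 `COc1cc(Cl)cc(-c2nn(-c3cccc(NC(=O)Nc4cccc(C(F)(F)F)c4)c3)cc2-c2ccncc2)c1` belongs to a pair built on one shared core. In a functional assay on OVCAR-3 cells (Homo sapiens) for inhibition, read by sulforhodamine B assay, with a stated time of 48 h, tested at 100 uM (a lower number here means a stronger effect, a higher number a weaker effect of the compound at the concentration tested), compound 2 gives -41%, the higher of the two numbers measured. Going by the values given here, compound 1 `COc1cc(Cl)cc(-c2nn(-c3cccc(NC(=O)Nc4ccc(Cl)c(C(F)(F)F)c4)c3)cc2-c2ccncc2)c1` gives -56% in this assay, and the only measured step, a number 15 percentage points higher from compound 1 to compound 2 (beyond the scatter), concerns the chloro group on an aromatic carbon. Compound 3 `COc1cc(Cl)cc(-c2nn(-c3cccc(NC(=O)c4cccc(C(F)(F)F)c4)c3)cc2-c2ccncc2)c1` differs from compound 2 in another place: 3-(trifluoromethyl)phenyl in place of (3-(trifluoromethyl)phenyl)amino on a carbonyl carbon. Among the compounds with values here, no measured step touches this part of the molecule, so the step from compound 1 to compound 2 offers no direct guide to the change. With one hydrogen-bond donor removed and nothing measured to anchor the guess, a weaker effect than compound 2 seems the more likely outcome, though a step within the scatter cannot be excluded. For compound 3 the expected value in this assay is -25%, within a range from -60% to 5%, which means an expected step of a number 16 percentage points higher from compound 2 to compound 3 (beyond the scatter).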

Compound 3, a percentage reported as activity, at one concentration (the size of the read-out at that concentration, not a potency): 38%
Compound 3: middle estimate off by 63 percentage points, on the low side; measured number above the stated range.
By their numbers in this assay, from the lowest: compound 1; then compound 2; then compound 3.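

In this assay, the change on the carbonyl carbon outweighs the earlier chloro change: 3-(trifluoromethyl)phenyl in place of (3-(trifluoromethyl)phenyl)amino gives a number 79 percentage points higher from compound 2 to compound 3 (beyond the scatter), a far larger step than a number 15 percentage points higher from compound 1 to compound 2 (beyond the scatter). Measured against the chloro-bearing urea-type compound, the combined change gives a number 94 percentage points higher from compound 1 to compound 3 (beyond the scatter), and compound 3, at 38%, is the only one of the three with a number above zero, so the amino part of this position matters greatly here. Nothing available explains why this step is so large.

Going by these compounds, it remains open whether another group on this carbonyl carbon, such as a benzyl group or a short alkylamine, would restore the effect. On these data alone, whether a chloro group would lower the number on the ring of compound 3 also remains unknown.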